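Ring exchange at the thiocarbonyl carbon: compound 4

A few compounds are considered here, and "the series" means these few. Any claim that something is new, unique, unknown or untested is made for them only; others in the source may bear on it.

Measured compounds:
compound 1, `Cc1cccc(/C(N)=N/NC(=S)N2CCSCC2)n1`: in a functional assay on HeLa cells (Homo sapiens) for cytotoxicity, read by MTT assay, with a stated time of 72 h, tested at 30 uM (a lower number here means less inhibition of growth, a higher number more inhibition of growth at the concentration tested), compound 1 gives 85.3%
compound 2, `N/C(=N\NC(=S)N1CCCCC1)c1ccccn1`: in this assay compound 2 gives 76.9%
compound 3, `Cc1cccc(/C(N)=N/NC(=S)N2CCOCC2)n1`: in this assay compound 3 gives 86.9%

Compound 3 holds the highest of the three numbers, but compound 1 and compound 2 both sit within the scatter of it, so no order among them can be read. Compound 4, `Cc1cccc(/C(N)=N/NC(=S)N2CCCCC2)n1`, differs from compound 3 by piperidin-1-yl in place of morpholin-4-yl on a thiocarbonyl carbon. Among the measured compounds shown here, the one step at this place, a number 1.6 percentage points higher from compound 1 to compound 3 (within the scatter), stayed within the scatter. Compound 2 also carries piperidin-1-yl yet lacks the methyl on the core, so its value only shows that this ring is compatible with strong inhibition. No step beyond the scatter is therefore expected in this assay. Compound 4 is estimated at 82%, range 70% to 92%, an expected step of a number 4.9 percentage points lower from compound 3 to compound 4 (within the scatter).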

Compound 4, percent growth inhibition at one concentration: 83.5%
Beside the measured number, compound 4's estimate is 1.5 percentage points below it; the range from low to high includes it.
By their numbers in this assay, from the lowest: compounds 2, 4, 1 and 3 (each within the scatter of the next).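

In this assay, the steps of a number 3.4 percentage points lower from compound 3 to compound 4 (within the scatter) and a number 1.8 percentage points lower from compound 1 to compound 4 (within the scatter) both lie within the scatter, so piperidin-1-yl, morpholin-4-yl and thiomorpholin-4-yl on the thiocarbonyl carbon cannot be told apart on the methyl-bearing core. Methyl in place of hydrogen on an aromatic carbon can now be read as a single change, and a number 6.6 percentage points higher from compound 2 to compound 4 (within the scatter) also lies within the scatter, so no effect of it can be read. No available evidence bears on these results.

Open, from the compounds shown here alone, is whether an open-chain diethylamino group or a piperidine ring carrying a carboxylic acid on the thiocarbonyl carbon would give a step beyond the scatter.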